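A few compounds are considered here, and "the series" means these few. Any claim that something is new, unique, unknown or untested is made for them only; others in the source may bear on it.

Measured in a functional assay on HCT-116 cells (Homo sapiens) for cytotoxicity, read by MTT assay, with a stated time of 48 h; a higher number here means a weaker inhibitor, a lower number a stronger inhibitor: compound 1 `O=C(/C=C/c1ccc2c(c1)B(O)OC2)c1ccccc1`, 6100 nM; compound 2 `O=C(/C=C/c1ccc2c(c1)B(O)OC2)c1ccc(I)cc1`, 11600 nM; compound 3 `O=C(/C=C/c1ccc2c(c1)B(O)OC2)c1ccccc1O`, 77900 nM.

Compound 3 gives the highest number of the three; a 13-fold higher number from compound 1 to compound 3 (1.11 log units; beyond the scatter) and a 6.7-fold higher number from compound 2 to compound 3 (0.83 log units; beyond the scatter) both place it beyond the scatter above the others. Compound 4 `O=C(/C=C/c1ccc2c(c1)B(O)OC2)c1cccc(O)c1` differs from compound 3 by 3-hydroxyphenyl in place of 2-hydroxyphenyl on a carbonyl carbon. Going by the values given here, no measured step moves a hydroxy from one ring carbon to another, so the direct bearing of this change is unknown. The nearest evidence is a 13-fold higher number from compound 1 to compound 3 (1.11 log units; beyond the scatter), in which the 2-hydroxyphenyl raised the number sharply against the plain phenyl of compound 1, whereas a 1.9-fold higher number from compound 1 to compound 2 (0.28 log units; within the scatter) stayed within the scatter. Whether the 3-hydroxyphenyl carries the same penalty cannot be read from these compounds; a partial return toward compound 1 is expected, with the estimated change being a 2.6-fold lower number from compound 3 to compound 4 (0.41 log units; beyond the scatter). Compound 4 is expected to give about 30000 nM in this assay, within 8000 nM to 100000 nM.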

Compound 4, half-maximal inhibitory concentration: 6500 nM
Compound 4: middle estimate off by 4.6-fold (0.66 log units), on the high side, and the stated range ends above it.
By their numbers in this assay, from the lowest: compounds 1, 4 and 2 (each within the scatter of the next); then compound 3.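

In (this assay), where the hydroxy sits on the phenyl decides the outcome (a 12-fold lower number from compound 3 to compound 4 (1.08 log units; beyond the scatter)), so the penalty of compound 3 belongs to the 2-hydroxyphenyl and not to a hydroxy as such. The 3-hydroxyphenyl stays level with the plain phenyl (a 1.1-fold higher number from compound 1 to compound 4 (0.03 log units; within the scatter)) and with the 4-iodophenyl (a 1.8-fold lower number from compound 2 to compound 4 (0.25 log units; within the scatter)), both within the scatter. Nothing measured here accounts for the gap between the two hydroxyphenyl groups.

On these data alone, whether a methoxy or an amine in place of the hydroxy keeps that gap between the two ring placements stays open.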